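The compounds below may be only part of what the source reports. "The series", "measured", "known", "first", "only" and "open" are said of these compounds alone.

Measured so far in a functional assay on DU-145 cells (Homo sapiens) for inhibition, read by trypan blue exclusion, with a stated time of 96 h; a lower number here means a stronger inhibitor of growth, a higher number a weaker inhibitor of growth:
- compound 1 `Cc1ccc(CS/C(=C/c2ccc(O)cc2)C(=O)c2ccc(Cl)cc2)cc1`: 10000 nM
- compound 2 `Cc1ccc(CS/C(=C/c2cc(C)ccc2C)C(=O)c2ccc(Cl)cc2)cc1`: 10000 nM
- compound 3 `Cc1ccc(CS/C(=C/c2cc(Cl)cc(Cl)c2)C(=O)c2ccc(Cl)cc2)cc1`: 10000 nM

Among the measured compounds shown here, on these numbers, compound 3 stands level with compound 1 and compound 2, and no member of the trio separates from the others.

The next change replaces 3,5-dichlorophenyl with 2-bromophenyl on a double-bonded chain carbon bound to a double-bonded chain carbon, which gives compound 4 `Cc1ccc(CS/C(=C/c2ccccc2Br)C(=O)c2ccc(Cl)cc2)cc1`. The difference is 2-bromophenyl in place of 3,5-dichlorophenyl on a double-bonded chain carbon bound to a double-bonded chain carbon.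

Three measured steps swap the group at this same place, and all of them bear on the new change: no change at the digits printed from compound 1 to compound 2 (within the scatter), no change at the digits printed from compound 1 to compound 3 (within the scatter) and no change at the digits printed from compound 2 to compound 3 (within the scatter). Very different groups thus left this assay unmoved. For the measured compounds named here, none of the measured compounds carries 2-bromophenyl, however, so the new group remains untested and the range has to stay wide.

No shift beyond the scatter is expected, and the estimated step is a 1.3-fold lower number from compound 3 to compound 4 (0.10 log units; within the scatter).

For compound 4 the estimate is 8000 nM, with an expected range from 2500 nM to 12000 nM.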

Compound 4, concentration for 50% growth inhibition: 10000 nM
Estimate against measurement, compound 4: 1.3-fold (0.10 log units) below, within the range that was stated.
By their numbers in this assay, from the lowest: compounds 1, 2, 3 and 4 (each within the scatter of the next).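

In this assay, placing 2-bromophenyl on a double-bonded chain carbon bound to a double-bonded chain carbon gives no change at the digits printed from compound 3 to compound 4 (within the scatter), no change at the digits printed from compound 2 to compound 4 (within the scatter) and no change at the digits printed from compound 1 to compound 4 (within the scatter). A bromine-bearing ring therefore joins the rings bearing hydroxyl, methyl and chlorine, and these four compounds do not separate from one another at this position. Nothing available explains why these different groups give the same reading.

As far as these compounds go, it remains open whether an amine or a carboxylic acid on this ring, or a longer chain in its place, would move the number in this assay. From the compounds shown here alone, it is also open whether a change elsewhere in the shared core would do so, since all four compounds differ only at this one place.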